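The compounds below may be only part of what the source reports. "The series", "measured", "known", "first", "only" and "open" are said of these compounds alone.

Measured compounds:
Compound 1, `COc1ccc(-c2ssc(=S)c2-c2cc(OC)c(OC)c(OC)c2)cc1O`: in a functional assay on HT-1080 cells (Homo sapiens) for antiproliferative activity, read by MTT assay, with a stated time of 72 h (a lower number here means a stronger inhibitor, a higher number a weaker inhibitor), compound 1 gives 231 nM.
Compound 2, `COc1ccc(-c2ssc(=S)c2-c2cc(OC)c(OC)c(OC)c2)cc1N`: in this assay compound 2 gives 834 nM.
Compound 3, `CO/N=c1/ssc(-c2ccc(OC)c(O)c2)c1-c1cc(OC)c(OC)c(OC)c1`: in this assay compound 3 gives 4600 nM.

Compound 1 and compound 2 share one core and differ in a single place: amino in place of hydroxy on an aromatic carbon. That change gives a 3.6-fold higher number from compound 1 to compound 2 (0.56 log units; beyond the scatter), a step that lies beyond the scatter of repeated measurements. Compound 3 carries a different core; how its core differs from that of compound 1 is not broken down here. What the two numbers show is that compound 3 stands with the highest value of the three, well beyond the scatter above both compound 1 and compound 2.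

Compound 4, `CO/N=c1/ssc(-c2ccc(OC)c(N)c2)c1-c1cc(OC)c(OC)c(OC)c1`, has not yet been measured. It stands to compound 3 as compound 2 stands to compound 1: amino in place of hydroxy on an aromatic carbon. The surroundings of the changed position are the same in both pairs, so this is the same change made on a second core. Among the compounds with values here, the only guide is the step on the first core. Compound 4 is therefore expected to give a higher number than compound 3, with the expected step of a 3.5-fold higher number from compound 3 to compound 4 (0.54 log units; beyond the scatter), because the same change gave a 3.6-fold higher number from compound 1 to compound 2 (0.56 log units; beyond the scatter) on the first core. Carrying a single measured step across to another core is uncertain, so the range is kept wide. For compound 4 the estimate is 16000 nM, expected to fall between 6000 nM and 40000 nM.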

Compound 4, half-maximal inhibitory concentration: 4230 nM
For compound 4 the middle estimate is 3.8-fold (0.58 log units) above the measured one; the measured number lies below the stated range.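

In this assay, putting amino in place of hydroxy on the core of compound 3 gives a 1.1-fold lower number from compound 3 to compound 4 (0.04 log units; within the scatter), so on this core the two compounds cannot be told apart, whereas the same change on the core of compound 1 gave a 3.6-fold higher number from compound 1 to compound 2 (0.56 log units; beyond the scatter). Within the data shown here, the size of the step therefore did not carry from one core to the other, even though the surroundings of the changed position are the same in both pairs, and the two steps stand clearly apart: the same change on two cores in this assay, a 3.6-fold higher number (0.56 log units; beyond the scatter) from compound 1 to compound 2 and a 1.1-fold lower number (0.04 log units; within the scatter) from compound 3 to compound 4, 3.9-fold (0.59 log units) apart, beyond the scatter of two such steps This shows that, in this series, a step measured on one core is not a safe guide to the same change on the other, but it rests on only two pairs and does not show which feature of the cores makes the difference, nor what the change would do on any further core.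

The compounds shown carry only hydroxy or amino at this place, so it stays open whether a fluoro group, an acetamido group or a hydroxymethyl group there would respond to the core in the same way. All of these numbers also come from a single cell line, which leaves open whether the contrast between the two cores holds in other cells.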